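The compounds below may be only part of what the source reports. "The series", "measured", "known", "first", "only" and "open" are said of these compounds alone.

Of the compounds shown here, three sharing one core have been measured in a functional assay on COLO 205 cells (Homo sapiens) for inhibition, read by sulforhodamine B assay, with a stated time of 48 h; a lower number here means a stronger inhibitor of growth, a higher number a weaker inhibitor of growth. Compound 1 `COc1cc(-c2nn(-c3cccc(NC(=O)c4cccc(C(F)(F)F)c4)c3)cc2-c2ccncc2)ccc1Cl` carries an amide whose carbonyl carbon bears a 3-(trifluoromethyl)phenyl group, and in this assay compound 1 gives 5170 nM. Compound 2 `COc1cc(-c2nn(-c3cccc(NC(=O)Nc4ccc(Cl)c(Cl)c4)c3)cc2-c2ccncc2)ccc1Cl` is a urea, and compound 2 gives 1720 nM. Compound 3 `COc1cc(-c2nn(-c3cccc(NC(=O)Nc4cccc(C(F)(F)F)c4)c3)cc2-c2ccncc2)ccc1Cl` is also a urea, and compound 3 gives 1750 nM. Compound 3 thus stands second highest of the three numbers: its value sits within the scatter of compound 2, as a 1.0-fold higher number from compound 2 to compound 3 (0.01 log units; within the scatter) shows, while compound 1 sits a clear step above it, as a 3.0-fold lower number from compound 1 to compound 3 (0.47 log units; beyond the scatter) shows.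

Compound 4 `COc1cc(-c2nn(-c3cccc(NC(=O)c4ccc(Cl)c(C(F)(F)F)c4)c3)cc2-c2ccncc2)ccc1Cl` has not yet been measured. It differs from compound 3 in one place: 4-chloro-3-(trifluoromethyl)phenyl in place of (3-(trifluoromethyl)phenyl)amino on a carbonyl carbon. This turns the urea of compound 3 back into an amide of the kind seen in compound 1. The step that bears on it is therefore the amide-to-urea step between compound 1 and compound 3, which gave a 3.0-fold lower number from compound 1 to compound 3 (0.47 log units; beyond the scatter); the parallel step a 3.0-fold lower number from compound 1 to compound 2 (0.48 log units; beyond the scatter) points the same way. Reversing that change is expected to raise the number by a modest amount, so compound 4 is expected to show a 2.6-fold higher number from compound 3 to compound 4 (0.41 log units; beyond the scatter) in this assay. The estimate for compound 4 is 4500 nM, with a range from 1800 nM to 11000 nM.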

Compound 4, concentration for total growth inhibition: 23300 nM
For compound 4 the middle estimate is 5.2-fold (0.71 log units) below the measured one; measured number above the stated range.
By their numbers in this assay, from the lowest: compounds 2 and 3 (each within the scatter of the next); then compound 1; then compound 4.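

In this assay a single chloro in place of hydrogen on an aromatic carbon of the amide gives a 4.5-fold higher number from compound 1 to compound 4 (0.65 log units; beyond the scatter) so this ring, and not only the link between amide and urea, affects how much compound is needed for total growth inhibition. The changes from the two ureas to compound 4 give a 13-fold higher number from compound 3 to compound 4 (1.12 log units; beyond the scatter) and a 14-fold higher number from compound 2 to compound 4 (1.13 log units; beyond the scatter) and both are larger than the earlier amide-to-urea step of a 3.0-fold lower number from compound 1 to compound 3 (0.47 log units; beyond the scatter) which fits with each of them combining the loss of the urea with the added chloro. The data give no measured reason for the weaker growth inhibition that comes with the chloro on this amide.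

The compounds shown leave open whether the same chloro would also raise the number in a urea, as a urea carrying 4-chloro-3-(trifluoromethyl)phenyl would show, since compound 4 is the only compound here with that group. They also leave open whether the rise belongs to chloro in particular or would also follow from a fluoro, a methyl or a methoxy group on that same aromatic carbon.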